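Removing the Ring Nitrogen Methyl: Expected Shift in Acid Dissociation

This account rests on a few compounds, and the source may have more. Where it says the series, first, only, none or still open, it means among the compounds named here.

Measured so far in a physicochemical assay for acid dissociation:
Compound 1, `CN1CCC=C(c2nc(N(C)C)no2)C1`, gives 7.24.
Compound 2, `CN(C)c1noc(C2=CCCNC2)n1`, gives 8.58.
Compound 3, `Cc1noc(C2=CC(C)CN(C)C2)n1`, gives 7.34.

Compound 1 and compound 2 differ in one place: hydrogen in place of methyl on an amine nitrogen in a ring. That change produced a number 1.34 log units higher from compound 1 to compound 2 (beyond the scatter). Compound 3 and compound 1 lie within the scatter of each other in this assay, so nothing is said about their order.

Compound 4, `Cc1noc(C2=CC(C)CNC2)n1`, has not yet been measured. It differs from compound 3 in one place: hydrogen in place of methyl on an amine nitrogen in a ring. Among the measured compounds shown here, this is the same kind of change as the one between compound 1 and compound 2, though the surroundings are not identical: in compound 1 the ring atom two ring bonds away bears a group of 8 heavy atoms, while in compound 3 one ring atom two ring bonds away bears a group of 6 heavy atoms and another bears a methyl group. How the core of compound 1 and the core of compound 3 differ is not broken down here.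

A step of a number 1.31 log units higher from compound 3 to compound 4 (beyond the scatter) is expected because the same kind of change earlier gave a number 1.34 log units higher from compound 1 to compound 2 (beyond the scatter). Compound 4 is therefore expected to give about 8.65 in this assay, most likely between 8.25 and 9.05.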

Compound 4, acid dissociation constant: 8.17
Compound 4: middle estimate off by 0.48 log units, on the high side; measured number outside the range, below it.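

In this assay, putting hydrogen in place of methyl on the amine nitrogen in the ring again raises the number, giving a number 0.83 log units higher from compound 3 to compound 4 (beyond the scatter), which matches the direction of the earlier a number 1.34 log units higher from compound 1 to compound 2 (beyond the scatter). So across these two pairs the direction carries from one core to the other, but the size does not stay fixed: the step is modest on the core of compound 3 and large on the core of compound 1, and two pairs cannot show how far either size would hold on a further core. No measurement at hand accounts for the difference in size between the two steps.

As far as these compounds go, the two cores differ in more than one feature, so it remains open which feature goes with the smaller step, such as the methyl group on the ring of compound 3. Also open, from the compounds shown here alone, is how the number would respond if the ring nitrogen carried an ethyl group or a longer chain instead of hydrogen or methyl.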